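Bromophenyl thioether and sulfone series on prostate cancer cells

The compounds below may be only part of what the source reports. "The series", "measured", "known", "first", "only" and "open" are said of these compounds alone.

Measured in a functional assay on DU-145 cells (Homo sapiens) for inhibition, read by trypan blue exclusion, with a stated time of 96 h; on this read-out higher numbers stand for weaker inhibition of growth and lower numbers for stronger inhibition of growth:
compound 1, `O=C(/C(=C\c1ccc(O)c([N+](=O)[O-])c1)S(=O)(=O)Cc1ccc(Br)cc1)c1c(F)c(F)c(F)c(F)c1F`, 50000 nM
compound 2, `O=C(/C(=C\c1ccc(O)c([N+](=O)[O-])c1)S(=O)(=O)Cc1ccc(Br)cc1)c1ccc(Br)cc1`, 10000 nM
compound 3, `O=C(/C(=C\c1ccc(O)c([N+](=O)[O-])c1)Sc1ccc(Br)cc1)c1c(F)c(F)c(F)c(F)c1F`, 1000 nM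

Compound 2 differs from compound 1 by 4-bromophenyl in place of 2,3,4,5,6-pentafluorophenyl on a carbonyl carbon, and in this assay this gives a 5.0-fold lower number from compound 1 to compound 2 (0.70 log units; beyond the scatter). Compound 3 differs from compound 1 by (4-bromophenyl)sulfanyl in place of (4-bromobenzyl)sulfonyl on a double-bonded chain carbon bound to a carbonyl carbon and a double-bonded chain carbon, which gives a 50-fold lower number from compound 1 to compound 3 (1.70 log units; beyond the scatter). Compound 3 holds the lowest number of the three; its steps to compound 2 and to compound 1 are both beyond the scatter.

Compound 4, `O=C(/C(=C\c1ccc(O)c([N+](=O)[O-])c1)Sc1ccc(Br)cc1)c1ccc(Br)cc1`, is not yet measured. It differs from compound 3 by 4-bromophenyl in place of 2,3,4,5,6-pentafluorophenyl on a carbonyl carbon. This is the same change as from compound 1 to compound 2, occurring twice among these compounds, at a place described in the same words each time. The two cores differ as set out under ((4-bromophenyl)sulfanyl in place of (4-bromobenzyl)sulfonyl on a double-bonded chain carbon bound to a carbonyl carbon and a double-bonded chain carbon).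

In this assay the step from compound 3 to compound 4 is expected to be a 3.3-fold lower number from compound 3 to compound 4 (0.52 log units; beyond the scatter), beside the earlier 5.0-fold lower number from compound 1 to compound 2 (0.70 log units; beyond the scatter); this rests on that one prior instance alone, so a somewhat smaller step is allowed for. Compound 4 is thus estimated at 300 nM, with a range from 80 nM to 1500 nM.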

Compound 4, concentration for 50% growth inhibition: 1000 nM
For compound 4 the middle estimate is 3.3-fold (0.52 log units) below the measured one, and the stated range covers the measured number.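

In this assay, 4-bromophenyl in place of 2,3,4,5,6-pentafluorophenyl on a carbonyl carbon gives no change at the digits printed from compound 3 to compound 4 (within the scatter). The change therefore does not carry over at the same size from the core of compound 1 to the core of compound 3: the same change on two cores in this assay, a 5.0-fold lower number (0.70 log units; beyond the scatter) from compound 1 to compound 2 and no change at the digits printed (within the scatter) from compound 3 to compound 4, 5.0-fold (0.70 log units) apart, beyond the scatter of two such steps. Among the compounds shown here, this shows that the step cannot be transferred between these two cores as a fixed increment, but with only one pair of steps it does not show which part of the core difference matters, as (4-bromophenyl)sulfanyl and (4-bromobenzyl)sulfonyl differ as whole units.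

The compounds shown leave open how (4-bromobenzyl)sulfanyl or (4-bromophenyl)sulfonyl would behave on the shared core, and these two groups would separate the sulfonyl from the benzyl part of the difference. Also open, as far as these compounds go, is whether the same core dependence would hold for a 4-aminophenyl or a 4-carboxyphenyl on the carbonyl carbon.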